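Swapping 2-carboxy-1H-indol-5-yl for pyridin-2-yl

A few compounds are considered here, and "the series" means these few. Any claim that something is new, unique, unknown or untested is made for them only; others in the source may bear on it.

Measured so far in a functional assay on DU-145 cells (Homo sapiens) for inhibition, read by trypan blue exclusion, with a stated time of 72 h; a lower number here means a stronger inhibitor, a higher number a weaker inhibitor
compound 1 `Cn1c(=O)c(S(=O)(=O)c2ccc(F)cc2F)cc2cnc(Nc3ccc4[nH]c(C(=O)O)cc4c3)nc21` gives 10000 nM
compound 2 `COc1ccc(Nc2ncc3cc(S(=O)(=O)c4ccc(C)cc4)c(=O)n(C)c3n2)cc1` gives 100000 nM
compound 3 `Cn1c(=O)c(S(=O)(=O)c2ccccc2)cc2cnc(Nc3ccc4ncccc4c3)nc21` gives 50000 nM

Compound 1 has the lowest number of the three, which makes it the strongest inhibitor of this small set. Its gaps to compound 3 and compound 2 both lie beyond the usual scatter.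

Compound 4 `Cn1c(=O)c(S(=O)(=O)c2ccc(F)cc2F)cc2cnc(Nc3ccccn3)nc21` keeps the core of compound 1 but carries pyridin-2-yl in place of 2-carboxy-1H-indol-5-yl on a nitrogen on an aromatic ring. Going by the values given here, no two measured compounds differ in just one place, so this change has no direct precedent. Among the compounds with values here, the only hint comes from compound 2 at 100000 nM and compound 3 at 50000 nM, which both lack the 2-carboxy-1H-indol-5-yl group and also differ elsewhere. A rise in this assay beyond the scatter is therefore expected, meaning a weaker inhibitor. The estimated step is a 3.0-fold higher number from compound 1 to compound 4 (0.48 log units; beyond the scatter) in that direction. Compound 4 is expected at 30000 nM with an estimated range from 8000 nM to 100000 nM as its likely span.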

Compound 4, half-maximal inhibitory concentration: 75000 nM
The estimate for compound 4 lay 2.5-fold (0.40 log units) below the measured number, and the stated range covers the measured number.
By their numbers in this assay, from the lowest: compound 1; then compounds 3, 4 and 2 (each within the scatter of the next).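

Going by these compounds alone, this is the first one-place comparison in this assay: on a nitrogen on an aromatic ring, pyridin-2-yl in place of 2-carboxy-1H-indol-5-yl gives a 7.5-fold higher number from compound 1 to compound 4 (0.88 log units; beyond the scatter). The earlier compounds shown here differed in several places at once, whereas here the rest of the molecule stays fixed, so the weaker inhibition can be tied to this single swap. Nothing measured here explains why this change weakens inhibition.

The swap removes both rings and the carboxy group of the departing substituent together, so the compounds shown cannot tell which of these parts matters. A plain 1H-indol-5-yl group, or the same indole carrying a methyl ester or a primary amide instead of the carboxylic acid, would begin to separate those contributions.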